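A Smaller Ring with an Acetamide Replaces Piperidine

A few compounds are considered here, and "the series" means these few. Any claim that something is new, unique, unknown or untested is made for them only; others in the source may bear on it.

Compound 1, `O=C(CCc1ccc(C(F)(F)F)cc1)Nc1ccc2nc(N3CCCCC3)ccc2c1`, gives 12 nM in an assay on isolated protein for displacement of a labelled ligand from melanin-concentrating hormone receptor 1 (Homo sapiens); a lower number here means a stronger inhibitor, a higher number a weaker inhibitor.
Compound 2, `O=C(CCc1ccc(C(F)(F)F)cc1)Nc1ccc2nc(N3CCCCCC3)ccc2c1`, gives 36 nM in this assay.
Compound 3, `CCCN(CCC)c1ccc2cc(NC(=O)CCc3ccc(C(F)(F)F)cc3)ccc2n1`, gives 490 nM in this assay.

All three share one core and one amide side chain and differ only in the amine on the aromatic carbon next to the ring nitrogen. Compound 1 has the lowest number of the three. Widening its ring by one carbon gives a 3.0-fold higher number from compound 1 to compound 2 (0.48 log units; beyond the scatter), while opening the ring into two propyl chains gives a 41-fold higher number from compound 1 to compound 3 (1.61 log units; beyond the scatter), and the same opening from compound 2 gives a 14-fold higher number from compound 2 to compound 3 (1.13 log units; beyond the scatter).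

Compound 4, `CC(=O)NC1CCN(c2ccc3cc(NC(=O)CCc4ccc(C(F)(F)F)cc4)ccc3n2)C1`, is not yet measured. It changes compound 1 as follows: 3-acetamidopyrrolidin-1-yl in place of piperidin-1-yl on an aromatic carbon. A five-membered ring takes the place of the six-membered one and carries an acetamide, so the change is both a ring size shift and a new polar group. The measured steps show that altering this amine weakens binding, mildly for a ring change and strongly for loss of the ring. For compound 4 a modest loss is therefore expected, with wide uncertainty. Compound 4 is estimated at 50 nM, within 8 nM to 300 nM, meaning an expected 4.2-fold higher number from compound 1 to compound 4 (0.62 log units; beyond the scatter).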

Compound 4, half-maximal inhibitory concentration: 5 nM
Compound 4: middle estimate off by 10-fold (1.00 log units), on the high side; measured number below the stated range.
By their numbers in this assay, from the lowest: compound 4; then compound 1; then compound 2; then compound 3.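

In this assay, among these compounds, the amine position proves able to take a larger group than piperidin-1-yl with a gain rather than a loss (a 2.4-fold lower number from compound 1 to compound 4 (0.38 log units; beyond the scatter)): every earlier change to the amine had raised the number, and 3-acetamidopyrrolidin-1-yl, with 9 heavy atoms against 6, is the first to lower it. The same group also stands well clear of the other two amines (a 7.2-fold lower number from compound 2 to compound 4 (0.86 log units; beyond the scatter); a 98-fold lower number from compound 3 to compound 4 (1.99 log units; beyond the scatter)), so compound 4 has the lowest number of the four, with all its steps beyond the scatter. Ring size alone therefore does not set the result at this position, although no measurement shown here explains why the number falls.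

From the compounds shown here alone, the step from compound 1 to compound 4 changes the ring and adds the acetamide together, so the share of each remains unknown. A plain pyrrolidin-1-yl would show the effect of the five-membered ring alone, while a piperidin-1-yl carrying an acetamide, or a pyrrolidin-1-yl carrying a free amine in its place, would test what the acetamide itself contributes.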